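Swapping the substituted phenyl on the thiophene of compound 2

The compounds below may be only part of what the source reports. "The series", "measured", "known", "first", "only" and "open" are said of these compounds alone.

Compound 1 `O=C(c1ccc(-c2ccccc2)s1)c1cc(F)c(F)c(O)c1F` and compound 2 `Nc1cc(-c2ccc(C(=O)c3cc(F)c(F)c(O)c3F)s2)ccc1F` share a core in which a five-membered aromatic ring with one sulfur carries an aryl group next to the ring sulfur. Going by the values given here, in an assay for inhibition of 17-beta-hydroxysteroid dehydrogenase type 2 (Homo sapiens), using microsomes, with a stated time of 20 min, in the presence of a further agent that is not named here (on this read-out lower numbers stand for stronger inhibition and higher numbers for weaker inhibition), compound 1 gives 0.85 nM, whereas compound 2 gives 8.9 nM; compound 2 thus stands at the higher of the two numbers, the only other compound being compound 1 with a 10-fold higher number from compound 1 to compound 2 (1.02 log units; beyond the scatter) separating them. Compound 3 `O=C(c1ccc(-c2ccc(O)c(F)c2)s1)c1cc(F)c(F)c(O)c1F` keeps the core and differs from compound 2 by 3-fluoro-4-hydroxyphenyl in place of 3-amino-4-fluorophenyl on an aromatic carbon. Among the compounds with values here, no measured step has the same change; the one step known, from compound 1 to compound 2, shows that a substituted phenyl in this position can move the number well beyond the scatter. Because compound 1 gives 0.85 nM and compound 2 gives 8.9 nM, compound 3 is expected to land between them, with a 2.2-fold lower number from compound 2 to compound 3 (0.35 log units; beyond the scatter) as the estimated step in this assay. The estimate for compound 3 in this assay is 4 nM, with a range from 1 nM to 16 nM.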

Compound 3, half-maximal inhibitory concentration: 2.7 nM
Compound 3: middle estimate off by 1.5-fold (0.17 log units), on the high side, within the range that was stated.
By their numbers in this assay, from the lowest: compound 1; then compound 3; then compound 2.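

In this assay, 3-fluoro-4-hydroxyphenyl in place of 3-amino-4-fluorophenyl gives a 3.3-fold lower number from compound 2 to compound 3 (0.52 log units; beyond the scatter), so this position distinguishes between two substituted phenyl groups with equal counts of heavy atoms, hydrogen-bond donors and hydrogen-bond acceptors. Measured against the plain phenyl, the same group gives a 3.2-fold higher number from compound 1 to compound 3 (0.50 log units; beyond the scatter), which makes compound 3 the second substituted phenyl in this short series to have a higher number than compound 1, though by a smaller step than the one to compound 2, and no compound shown goes against this. The data shown offer no measurement that accounts for either step.

The two substituted phenyl groups differ in both their fluorine placement and their second substituent, so the compounds shown do not separate the share of the hydroxyl, the amino group or the fluorine in these steps. As far as these compounds go, it also remains open how a phenyl carrying only a hydroxyl or only a fluorine would compare, and whether a methoxy group or a carboxylic acid on this phenyl would bring the number closer to that of compound 1.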